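This account rests on a few compounds, and the source may have more. Where it says the series, first, only, none or still open, it means among the compounds named here.

Compound 1 `Cc1ccc(Nc2nnc(Nc3nc(-c4ccc(Cl)cc4)cs3)s2)cc1` and compound 2 `COc1ccc(Nc2nnc(Nc3nc(-c4ccc(Cl)cc4)cs3)s2)cc1` share one core and differ only by methoxy in place of methyl on an aromatic carbon. In a functional assay on the whole organism (strain albino) with Mus musculus as the target, in the maximal electroshock model, with a stated time of 4 h (on this read-out lower numbers stand for an effect already at smaller amounts and higher numbers for an effect only at larger amounts of compound), compound 1 gives 100 mg/kg, while compound 2 gives 300 mg/kg, so the change brings a 3.0-fold higher number from compound 1 to compound 2 (0.48 log units; beyond the scatter). Compound 3 `Cc1ccc(Nc2nnc(Nc3nc(-c4ccc(Br)cc4)cs3)s2)cc1` has the other core, set apart from compound 1 by bromo in place of chloro on an aromatic carbon; in this assay compound 3 gives 100 mg/kg, which amounts to no change at the digits printed from compound 1 to compound 3 (within the scatter). For the measured compounds named here, compound 4 `COc1ccc(Nc2nnc(Nc3nc(-c4ccc(Br)cc4)cs3)s2)cc1`, still unmeasured, differs from compound 3 by methoxy in place of methyl on an aromatic carbon, the same change made at the same place as the one that took compound 1 to compound 2. Because compound 1 and compound 3 sit level at no change at the digits printed from compound 1 to compound 3 (within the scatter), the earlier step is expected to repeat, roughly a 3.0-fold higher number from compound 3 to compound 4 (0.48 log units; beyond the scatter). Compound 4 is therefore estimated at 300 mg/kg in this assay, most likely between 100 mg/kg and 1000 mg/kg.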

Compound 4, minimum effective dose: 100 mg/kg
Compound 4: middle estimate off by 3.0-fold (0.48 log units), on the high side; low and high end bracket the measured number.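

With methoxy in place of methyl on the core of compound 3, this assay shows no change at the digits printed from compound 3 to compound 4 (within the scatter), so the step seen on the core of compound 1 does not carry over: the same change on two cores in this assay, a 3.0-fold higher number (0.48 log units; beyond the scatter) from compound 1 to compound 2 and no change at the digits printed (within the scatter) from compound 3 to compound 4, 3.0-fold (0.48 log units) apart, beyond the scatter of two such steps.
Read the other way, bromo in place of chloro brings a 3.0-fold lower number from compound 2 to compound 4 (0.48 log units; beyond the scatter), which sets it apart from the same change made with methyl in the molecule: the same change on two cores in this assay, no change at the digits printed (within the scatter) from compound 1 to compound 3 and a 3.0-fold lower number (0.48 log units; beyond the scatter) from compound 2 to compound 4, 3.0-fold (0.48 log units) apart, beyond the scatter of two such steps.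
The two changes therefore do not add up independently across these four compounds, but this does not show why, nor how either step would behave on any other core.

The compounds shown leave open whether this gap between the steps would hold with an ethyl group, a hydroxyl or an amine at the same place. Fluoro in place of chloro also remains open.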